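This account rests on a few compounds, and the source may have more. Where it says the series, first, only, none or still open, it means among the compounds named here.

Measured in a physicochemical assay for solubility, read by spectrophotometry, in phosphate buffer, with a stated time of 18 h, at pH 7.4; a lower number here means a less soluble compound, a higher number a more soluble compound:
- compound 1 `CCc1ccc(-c2nc3c(c(C)nn3-c3ccccc3)c(-c3ccccc3[N+](=O)[O-])c2C#N)cc1`: 1200 nM
- compound 2 `CCc1ccc(-c2nc3c(c(C)nn3-c3ccccc3)c(-c3ccccc3C(F)(F)F)c2C#N)cc1`: 11000 nM
- compound 3 `CCc1ccc(-c2nc3c(c(C)nn3-c3ccccc3)c(-c3ccccc3OC(F)(F)F)c2C#N)cc1`: 9900 nM

In this assay, compound 3 gives 9900 nM, level with compound 2. The step of a 1.1-fold lower number from compound 2 to compound 3 (0.05 log units; within the scatter) does not separate them, whereas the step of an 8.3-fold higher number from compound 1 to compound 3 (0.92 log units; beyond the scatter) sets compound 3 clearly apart from compound 1.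

The next compound is compound 4 `CCc1ccc(-c2nc3c(c(C)nn3-c3ccccc3)c(-c3ccc(O)cc3)c2C#N)cc1`. The change is 4-hydroxyphenyl in place of 2-(trifluoromethoxy)phenyl on an aromatic carbon, opposite the ring nitrogen and ortho to a cyano group.

Going by the values given here, all three measured steps bear on this same aromatic carbon, but only indirectly, since none of the measured compounds carries 4-hydroxyphenyl. Among the compounds with values here, the largest are a 9.2-fold higher number from compound 1 to compound 2 (0.96 log units; beyond the scatter) and an 8.3-fold higher number from compound 1 to compound 3 (0.92 log units; beyond the scatter), both modest, and they show how far a change in this group has moved the number so far. The step between compound 2 and compound 3 offers no guide to direction, so the expectation rests mainly on compound 1 at 1200 nM, the lowest value measured in this small set.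

A modest drop is expected in this assay, smaller than those largest steps, and the expected step is a 2.2-fold lower number from compound 3 to compound 4 (0.34 log units; beyond the scatter). Compound 4 is estimated at 4500 nM, with an expected range of 1200 nM to 17000 nM.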

Compound 4, solubility: 5700 nM
Compound 4: middle estimate off by 1.3-fold (0.10 log units), on the low side, within the range that was stated.
By their numbers in this assay, from the lowest: compound 1; then compounds 4, 3 and 2 (each within the scatter of the next).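

In this assay, going by these compounds alone, compound 4 is the first in the set whose group on this aromatic carbon, opposite the ring nitrogen and ortho to a cyano group, is not a 2-substituted phenyl, yet neither a 1.7-fold lower number from compound 3 to compound 4 (0.24 log units; within the scatter) nor a 1.9-fold lower number from compound 2 to compound 4 (0.29 log units; within the scatter) separates it from the two fluorinated compounds. Only a 4.8-fold higher number from compound 1 to compound 4 (0.68 log units; beyond the scatter) is a step beyond the scatter, so among the four groups seen at this carbon, 2-nitrophenyl alone stands apart, and a hydrogen-bond donor can enter here, on the 4-hydroxyphenyl group, without a step from the fluorinated compounds beyond the scatter. The data shown offer no measurement that would explain the way these numbers fall.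

Since 4-hydroxyphenyl differs from the other groups both in the kind of substituent and in where it sits on the phenyl ring, the compounds shown leave open which of the two matters here; 2-hydroxyphenyl on the same core would separate them. On these data alone, it also remains open how this carbon would respond to a phenyl ring carrying an amine or a carboxylic acid at the 4-position.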